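Nitro substitution on the fused ring: notes toward compound 4

This account rests on a few compounds, and the source may have more. Where it says the series, first, only, none or still open, it means among the compounds named here.

Compound 1 `CCn1cc(-c2nc3ccccc3[nH]2)c(=O)c2cc(F)c(N3CCNCC3)nc21` is the reference of the set. In a functional assay on KB cells (Homo sapiens) for cytotoxicity, read by MTT assay, with a stated time of 48 h (on this read-out higher numbers stand for weaker inhibition and lower numbers for stronger inhibition), compound 1 gives 2000 nM. Compound 3 `CCn1cc(-c2nc3ccc([N+](=O)[O-])cc3[nH]2)c(=O)c2cc(F)c(N3CCNCC3)nc21` carries the change nitro in place of hydrogen on an aromatic carbon
In this assay compound 3 gives 22400 nM, and the change yields an 11-fold higher number from compound 1 to compound 3 (1.05 log units; beyond the scatter). Compound 2 `CCn1cc(-c2nc3ccccc3o2)c(=O)c2cc(F)c(N3CCNC(C)C3)c(F)c21` rests on a different core; the difference between the two cores is not broken down here. In this assay compound 2 gives 18900 nM. Compound 4 `CCn1cc(-c2nc3ccc([N+](=O)[O-])cc3o2)c(=O)c2cc(F)c(N3CCNC(C)C3)c(F)c21` is the unmeasured member, differing from compound 2 by nitro in place of hydrogen on an aromatic carbon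
The surroundings of the place are described in the same words as for the change from compound 1 to compound 3, so this is the same change. For compound 4 the step of a 5.3-fold higher number from compound 2 to compound 4 (0.72 log units; beyond the scatter) is expected, resting on the single earlier occurrence, which gave an 11-fold higher number from compound 1 to compound 3 (1.05 log units; beyond the scatter). Compound 4 is accordingly estimated at 100000 nM, expected between 30000 nM and 300000 nM.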

Compound 4, half-maximal inhibitory concentration: 600 nM
Compound 4: middle estimate off by 170-fold (2.22 log units), on the high side, and the stated range ends above it.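

In this assay, nitro in place of hydrogen on an aromatic carbon gives a 32-fold lower number from compound 2 to compound 4 (1.50 log units; beyond the scatter), opposite in direction to its earlier occurrence, so the step did not carry from one core to the other: the same change on two cores in this assay, an 11-fold higher number (1.05 log units; beyond the scatter) from compound 1 to compound 3 and a 32-fold lower number (1.50 log units; beyond the scatter) from compound 2 to compound 4, 350-fold (2.55 log units) apart, beyond the scatter of two such steps

On these two cores, then, the step on one gives neither the size nor the direction of the step on the other. It does not show which difference between the cores goes with the reversal, as the two pairs differ in more than one place and each core offers a single occurrence.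

As far as these compounds go, whether an amine or a carboxylic acid in place of the nitro would also split between the two cores remains open. Also open, from the compounds shown here alone, is how the step behaves on a core carrying only one of the differences between the core of compound 1 and the core of compound 2.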